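This account rests on a few compounds, and the source may have more. Where it says the series, first, only, none or still open, it means among the compounds named here.

In a functional assay on DU-145 cells (Homo sapiens) for cytotoxicity, read by MTT assay, with a stated time of 48 h (a lower number here means a stronger inhibitor, a higher number a weaker inhibitor), three compounds with the same core differ only in the phenyl group on an aromatic nitrogen. Compound 1 `COc1cccc(-n2cc(COc3ccc(/C=C4\C[C@]5(C)[C@@H](CC/C=C(\C)CC/C=C(\C)CCC=C(C)C)[C@](C)(O)CC[C@H]5C(C)(C)C4=O)cc3)nn2)c1`, with 3-methoxyphenyl, gives 14500 nM. Compound 2 `CC(C)=CCC/C(C)=C/CC/C(C)=C/CC[C@@H]1[C@@]2(C)C/C(=C\c3ccc(OCc4cn(-c5ccc(F)cc5)nn4)cc3)C(=O)C(C)(C)[C@@H]2CC[C@@]1(C)O`, with 4-fluorophenyl, gives 33600 nM, and compound 3 `CC(C)=CCC/C(C)=C/CC/C(C)=C/CC[C@@H]1[C@@]2(C)C/C(=C\c3ccc(OCc4cn(-c5cccc([N+](=O)[O-])c5)nn4)cc3)C(=O)C(C)(C)[C@@H]2CC[C@@]1(C)O`, with 3-nitrophenyl, gives 46400 nM. Compound 3 cannot be told apart from its nearest neighbour: the gap, a 1.4-fold higher number from compound 2 to compound 3 (0.14 log units; within the scatter), lies within the scatter. The gap on the other side, a 3.2-fold higher number from compound 1 to compound 3 (0.51 log units; beyond the scatter), lies beyond it, as does a 2.3-fold higher number from compound 1 to compound 2 (0.36 log units; beyond the scatter), though both are modest.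

Going by the values given here, compound 4 `CC(C)=CCC/C(C)=C/CC/C(C)=C/CC[C@@H]1[C@@]2(C)C/C(=C\c3ccc(OCc4cn(-c5ccc(F)c(Cl)c5)nn4)cc3)C(=O)C(C)(C)[C@@H]2CC[C@@]1(C)O` changes only this group: 3-chloro-4-fluorophenyl in place of 3-nitrophenyl on an aromatic nitrogen. Among the compounds with values here, it has 3-chloro-4-fluorophenyl, which keeps the fluorine of compound 2 and adds a chlorine that no measured compound carries. Within the data shown here, the measured swaps at this place have all been small, and the one between compound 2 and compound 3 did not exceed the scatter. A similarly small result is therefore expected here, with no step beyond the scatter. The estimated step is a 1.4-fold lower number from compound 3 to compound 4 (0.15 log units; within the scatter). The estimate for compound 4 is 33000 nM, with an expected range from 15000 nM to 70000 nM.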

Compound 4, half-maximal inhibitory concentration: 28400 nM
The estimate for compound 4 lay 1.2-fold (0.07 log units) above the measured number; the range from low to high includes it.
By their numbers in this assay, from the lowest: compounds 1, 4, 2 and 3 (each within the scatter of the next, the first and the last beyond it).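

Adding a chlorine to the 4-fluorophenyl group gives a 1.2-fold lower number from compound 2 to compound 4 (0.07 log units; within the scatter), so this second halogen on the ring makes no difference that can be read in this assay. The swap from a nitro-bearing ring to this doubly halogenated one gives a 1.6-fold lower number from compound 3 to compound 4 (0.21 log units; within the scatter), and the swap from the methoxy-bearing ring gives a 2.0-fold higher number from compound 1 to compound 4 (0.29 log units; within the scatter), so the new compound cannot be told apart from any of the earlier three, even though compound 1 and compound 3 do differ beyond the scatter. No supporting measurement is available to explain these results.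

As far as these compounds go, whether an amine or a carboxylic acid on this phenyl ring would move the number further remains open. So does the effect of replacing the ring with a longer chain.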